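A few compounds are considered here, and "the series" means these few. Any claim that something is new, unique, unknown or untested is made for them only; others in the source may bear on it.

Measured compounds in this series:

compound 1 `C=CC1=C(C(=O)NCc2ccc(C)cc2)C(c2ccc(F)cc2)OC1`: 62100 nM
compound 2 `C=CC1=C(C(=O)O)C(c2ccc(F)cc2)OC1`: > 100000 nM (a limit)
compound 3 `C=CC1=C(C(=O)NC(C)(C)C)C(c2ccc(OC)cc2)OC1`: > 100000 nM (a limit)

Going by the values given here, in a functional assay on QGY7701 cells (Homo sapiens) for cytotoxicity, read by MTT assay, with a stated time of 24 h (a higher number here means a weaker inhibitor, a lower number a stronger inhibitor), compound 1 gives 62100 nM, the only finite number in the set. Compound 2 returns only a limit of the assay, > 100000 nM. Compound 3 likewise returns only a limit, > 100000 nM. Among the compounds with values here, compound 1 therefore stands as the single compound with a measured number, while the other two sit at the limit of > 100000 nM in this assay, at which 2 of the 3 values shown sit. Within the data shown here, no two measured compounds differ in one place, so no measured step exists to lean on.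

Compound 4, `C=CC1=C(C(=O)NCc2ccccc2F)C(c2ccc(F)cc2)OC1`, is yet to be measured in this assay. It differs from compound 1 by 2-fluorophenyl in place of 4-methylphenyl on a saturated chain carbon bound to an amide-type nitrogen. Among the measured compounds shown here, with no comparable step in the set, the expectation rests on compound 1 alone, whose value is 62100 nM. No step beyond the usual scatter is expected in either direction. Compound 4 is estimated at 70000 nM, with a range from 25000 nM to 200000 nM. For compound 4 the expected step is a 1.1-fold higher number from compound 1 to compound 4 (0.05 log units; within the scatter). A sizeable chance remains that the assay reports only a limit for compound 4.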

Compound 4, half-maximal inhibitory concentration: 51400 nM
Estimate against measurement, compound 4: 1.4-fold (0.13 log units) above; measured number inside the range.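

The step at this position in this assay is a 1.2-fold lower number from compound 1 to compound 4 (0.08 log units; within the scatter). For this one pair, 2-fluorophenyl and 4-methylphenyl on a saturated chain carbon bound to an amide-type nitrogen cannot be told apart by this read-out, so 4-methylbenzyl is not required for the measured number of compound 1. Compound 4 also gives a finite number, making it a second benzyl amide that does not sit at the limit of the assay: the limit of > 100000 nM in this assay, at which 2 of the 4 values shown sit.

Going by these compounds, whether plain benzyl, 4-fluorobenzyl or a longer chain between the amide nitrogen and the aromatic ring would give a step beyond the scatter stays open. So does the effect of an amine on that aromatic ring, since only two substituted benzyl groups can be compared here.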